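From tert-butoxy to neopentyl: working notes on compound 4

A few compounds are considered here, and "the series" means these few. Any claim that something is new, unique, unknown or untested is made for them only; others in the source may bear on it.

Three compounds with a shared core have so far entered a functional assay on MDA-MB-231 cells (Homo sapiens) for cytotoxicity, read by MTT assay, with a stated time of 48 h; a higher number here means a weaker inhibitor, a lower number a stronger inhibitor. Compound 1 (`COc1ccc(NC(=O)[C@@H]2Cc3ccc(OCC(=O)NO)cc3CN2C(=O)CCCc2ccccc2)cc1`) gives 2770 nM in this test. Compound 3 (`CC[C@H](C)[C@@H](CN1Cc2cc(OCC(=O)NO)ccc2C[C@H]1C(=O)Nc1ccc(OC)cc1)NC(=O)OC(C)(C)C`) gives 2200 nM under the same conditions. For the measured compounds named here, these two numbers lie within the scatter of each other, so compound 3 stands level with the only other number available. For compound 2 (`CC[C@H](C)[C@H](NC(=O)[C@@H](NC(=O)OC(C)(C)C)C(C)C)C(=O)N1Cc2cc(OCC(=O)NO)ccc2C[C@H]1C(=O)Nc1ccc(OC)cc1`) the entry reads "not determined" (no result reported) and adds no number to the comparison.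

The next compound to be tested is compound 4 (`CC[C@H](C)[C@@H](CN1Cc2cc(OCC(=O)NO)ccc2C[C@H]1C(=O)Nc1ccc(OC)cc1)NC(=O)CC(C)(C)C`). It differs from compound 3 in one place: neopentyl in place of tert-butoxy on a carbonyl carbon. Cut one bond further out, the same difference reads tert-butoxycarbonyl to neopentylcarbonyl.

Going by the values given here, no measured pair differs in one place only, so the data offer no direct precedent for this change. The expectation therefore starts from compound 3 at 2200 nM as the reference number. Expected in this assay is a 1.1-fold higher number from compound 3 to compound 4 (0.04 log units; within the scatter) and nothing beyond the scatter, with no direction supported by the data. The estimate for compound 4 is 2400 nM with an expected range of 1000 nM to 5500 nM in this measurement.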

Compound 4, half-maximal inhibitory concentration: 2540 nM
Compound 4: middle estimate off by 1.1-fold (0.02 log units), on the low side; the measured number falls inside the stated range.
By their numbers in this assay, from the lowest: compounds 3, 4 and 1 (each within the scatter of the next).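

In this assay the series now has its first reading between compounds that differ in one place: a 1.2-fold higher number from compound 3 to compound 4 (0.06 log units; within the scatter), for neopentyl in place of tert-butoxy on a carbonyl carbon with an amide-type nitrogen as its other neighbour. With the count of heavy atoms the same, this exchange replaces the oxygen of tert-butoxy and its one hydrogen-bond acceptor with carbon, and in this single pair the two numbers stay within the scatter of each other, so the acceptor count at this position does not separate them here. No measurement available bears on this result.

This one pair cannot show whether the same holds for groups of a different kind on this carbonyl carbon, such as a primary amine, a carboxylic acid or a longer alkyl chain in place of neopentyl. For the compounds shown here, it also leaves open how far the numbers in this assay can move through this position at all, since the only step available lies within the scatter.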